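The compounds below may be only part of what the source reports. "The series", "measured", "known", "first", "only" and "open" are said of these compounds alone.

Working notes on the series. Within the data shown here, in an assay on isolated protein for activation of Nicotinamide phosphoribosyltransferase (Homo sapiens) (a higher number here means that more compound is needed for the effect, a lower number that less compound is needed), compound 2 `CN(C)S(=O)(=O)c1ccc(NC(=O)NCc2ccncc2)cc1` gives 3110 nM, the highest of the two numbers so far; compound 1 `O=C(NCc1ccncc1)Nc1ccc(S(=O)(=O)N2CCc3ccccc3C2)cc1` gives 142 nM. Among the measured compounds shown here, the one step measured, a 22-fold higher number from compound 1 to compound 2 (1.34 log units; beyond the scatter), shows a large change at the sulfonyl sulfur. Compound 3 `O=C(NCc1ccncc1)Nc1ccc(S(=O)(=O)c2cccc(Cl)c2)cc1` carries 3-chlorophenyl in place of dimethylamino on a sulfonyl sulfur, partly reversing the direction of that step by returning a ring to the same place, though a different one. A lower number than compound 2 is expected, roughly estimated as a 6.2-fold lower number from compound 2 to compound 3 (0.79 log units; beyond the scatter). For compound 3 the estimate in this assay is 500 nM, with a range from 120 nM to 2000 nM.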

Compound 3, half-maximal effective concentration: 69 nM
Compound 3: middle estimate off by 7.2-fold (0.86 log units), on the high side, outside the stated range (below it).
By their numbers in this assay, from the lowest: compound 3; then compound 1; then compound 2.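

At the sulfonyl sulfur in this assay, the gain does not need an attached nitrogen: a 45-fold lower number from compound 2 to compound 3 (1.65 log units; beyond the scatter) comes with 3-chlorophenyl, joined through aromatic carbon. The same group also edges past 1,2,3,4-tetrahydroisoquinolin-2-yl, with a 2.1-fold lower number from compound 1 to compound 3 (0.31 log units; beyond the scatter) as a modest step. No measurement on hand accounts for either step.

Open, from the compounds shown here alone, is what the chlorine itself contributes, and whether plain phenyl or a pyridyl ring on the sulfonyl sulfur would give a similar number. Also open, going by these compounds, is whether a piperidine ring, a saturated amine, would hold up there as the 1,2,3,4-tetrahydroisoquinolin-2-yl group does.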